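The compounds below may be only part of what the source reports. "The series", "measured", "known", "first", "only" and "open" are said of these compounds alone.

Measured so far:
- compound 1 `CC1CC=C(C(=O)N(c2cc(C#CC(C)(C)C)sc2C(=O)O)C(C)C)CC1`: 0.08
- compound 2 `CC(C)(C)C#Cc1cc(N(CCO)C(=O)[C@H]2CC[C@H](C)CC2)c(C(=O)O)s1`: "not determined" (no result reported)
- compound 3 `CC(C)(C)C#Cc1cc(N(C(=O)[C@H]2CC[C@H](C)CC2)[C@H]2CC[C@H](O)CC2)c(C(=O)O)s1`: 0.19

In an ADME assay for protein binding, using equilibrium dialysis, at pH 7.4, tested at 2 uM (on this read-out lower numbers stand for a smaller free fraction and higher numbers for a larger free fraction), compound 1 gives 0.08, and compound 3 gives 0.19. Going by the values given here, compound 1 stands at the lower of the two numbers known; the gap up to compound 3 is beyond the scatter, so compound 3 is the one with the larger free fraction of the two. Among the compounds with values here, for compound 2 this assay reports no number, so only compound 1 and compound 3 are available for comparison, and the two differ from each other in more than one place, so no single step between them is isolated.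

Compound 4 `CC(C)N(C(=O)C1CCC(F)(F)CC1)c1cc(C#CC(C)(C)C)sc1C(=O)O` has not yet been measured. It differs from compound 1 in one place: 4,4-difluorocyclohexyl in place of 4-methylcyclohex-1-en-1-yl on a carbonyl carbon. The shared core, the amide-type nitrogen and its substituent are unchanged. Within the data shown here, no measured pair shows this kind of change, so the expectation rests on compound 1 alone. A small step is expected, from compound 1 to compound 4 of a 1.3-fold higher number from compound 1 to compound 4 (0.10 log units; within the scatter), not beyond the scatter, leaning if anything towards a slightly larger free fraction. For compound 4 an unbound fraction of 0.1 is estimated, with a range from 0.05 to 0.2.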

Compound 4, unbound fraction: 0.4
Estimate against measurement, compound 4: 4.0-fold (0.60 log units) below; measured number above the stated range.
By their numbers in this assay, from the lowest: compound 1; then compound 3; then compound 4.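

In this assay, the group on the carbonyl carbon can move the read-out on its own: with the shared core, the amide-type nitrogen and its substituent unchanged, 4,4-difluorocyclohexyl in place of 4-methylcyclohex-1-en-1-yl gives a 5.0-fold higher number from compound 1 to compound 4 (0.70 log units; beyond the scatter). Going by these compounds alone, this is the first single-place step, and it makes this position one where a ring-for-ring change with no difference in counted donors, acceptors or net charge still separates two compounds beyond the scatter. The change alters several features at once, since the double bond and the methyl leave while two fluorines enter, and nothing available accounts for the size of the step.

Which of these features carries the step remains open, and a plain cyclohexyl or a 4-fluorocyclohexyl on the same carbonyl carbon would begin to separate them. Also open, on these data alone, is whether the step holds with a different substituent on the amide-type nitrogen, or whether a ring carrying an amine at this position would shift the free fraction in the same direction.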